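The compounds below may be only part of what the source reports. "The series", "measured", "known", "first", "only" and "open" are said of these compounds alone.

Compound 1 `COc1ccc(CN(C(=O)CCCl)c2cc(OC)c(OC)c(OC)c2)cc1O` carries a (2-chloroethyl)carbonyl on the amide-type nitrogen of the shared core. In a functional assay on MGC-803 cells (Homo sapiens) for inhibition, read by MTT assay, with a stated time of 48 h (on this read-out higher numbers stand for weaker inhibition and lower numbers for stronger inhibition), compound 1 gives 140 nM, the lowest of the three numbers in hand. Among the compounds with values here, compound 2 `C/C=C/C(=O)N(Cc1ccc(OC)c(OC)c1)c1cc(OC)c(OC)c(OC)c1` gives 20100 nM and compound 3 `C/C=C/C(=O)N(Cc1ccc(OC)c(F)c1)c1cc(OC)c(OC)c(OC)c1` gives 1650 nM; each differs from compound 1 in more than one place, so no single step joins either of them to compound 1. Within the data shown here, the only one-place step measured so far is a 12-fold lower number from compound 2 to compound 3 (1.09 log units; beyond the scatter), a change on an aromatic carbon.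

Compound 4 `COc1ccc(CN(C(=O)C(C)C)c2cc(OC)c(OC)c(OC)c2)cc1O` has not yet been measured in this assay. It differs from compound 1 by isopropyl in place of 2-chloroethyl on a carbonyl carbon. Among the measured compounds shown here, no measured step bears on this change: the step from compound 2 to compound 3 sits on an aromatic carbon and leaves the carbonyl carbon and its substituent untouched, and no other pair differs at this position. The data therefore set neither the size nor the direction of the step in this assay for this change, and the estimate rests on compound 1 alone with wide bounds.

The expected step is a 5.0-fold higher number from compound 1 to compound 4 (0.70 log units; beyond the scatter). Compound 4 is estimated at 700 nM, with a range from 100 nM to 5000 nM.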

Compound 4, half-maximal inhibitory concentration: 210 nM
Estimate against measurement, compound 4: 3.3-fold (0.52 log units) above, and the stated range covers the measured number.
By their numbers in this assay, from the lowest: compounds 1 and 4 (each within the scatter of the next); then compound 3; then compound 2.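

In this assay the position on the carbonyl carbon now has its first reading, a 1.5-fold higher number from compound 1 to compound 4 (0.18 log units; within the scatter), so at this position in this pair isopropyl stands in place of 2-chloroethyl with no difference beyond the scatter. The two groups have the same count of heavy atoms, but the chlorine of 2-chloroethyl is gone in compound 4, and in this pair the number stays of the same order without it, whereas the earlier one-place step touched only an aromatic carbon and said nothing about this site. Within the data shown here, nothing measured so far accounts for this result, and steps from compound 1 or compound 4 to compound 2 or compound 3 cannot be read, as those pairs differ in more than one place.

Still open, going by these compounds, is what a longer chain such as n-butyl, a ring such as cyclopropyl, or a chain ending in a dimethylamine would give on the same carbonyl carbon. Also open, on these data alone, is whether fluoro in place of methoxy on an aromatic carbon, read so far only as a 12-fold lower number from compound 2 to compound 3 (1.09 log units; beyond the scatter), gives a step of like size when isopropylcarbonyl or (2-chloroethyl)carbonyl is present.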